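Sulfonyl ring exchange in a three-compound clearance series

The compounds below may be only part of what the source reports. "The series", "measured", "known", "first", "only" and "open" are said of these compounds alone.

Measured in an ADME assay on microsomes from liver (Homo sapiens) for pharmacokinetics, read by LC-MS, with a stated time of 60 min, tested at 1 uM; on this read-out lower numbers stand for slow clearance and higher numbers for fast clearance
compound 1 `O=C(NCc1ccc(S(=O)(=O)c2ccccc2)cc1)N1Cc2ccncc2C1` gives 7.5 mL/min/kg
compound 2 `O=C(NCc1ccc(S(=O)(=O)c2cccc(C(F)(F)F)c2)cc1)N1Cc2ccncc2C1` gives 14 mL/min/kg
compound 3 `O=C(NCc1ccc(S(=O)(=O)C2CCC(F)(F)CC2)cc1)N1Cc2ccncc2C1` gives 6 mL/min/kg

Compound 3 cannot be separated from compound 1, but it does separate from compound 2. The nearest guides are the changes on the sulfonyl sulfur, a 1.3-fold lower number from compound 1 to compound 3 (0.10 log units; within the scatter) and a 2.3-fold lower number from compound 2 to compound 3 (0.37 log units; beyond the scatter), the first within the scatter and the second modest. Among the measured compounds shown here, compound 4 `O=C(NCc1ccc(S(=O)(=O)C2CCCOC2)cc1)N1Cc2ccncc2C1` has oxan-3-yl in place of 4,4-difluorocyclohexyl on a sulfonyl sulfur, counted as oxan-3-yl in place of 4,4-difluorocyclohexyl on a sulfonyl sulfur and covered by no measured step. No step beyond the scatter is therefore expected. The expected step is a 1.1-fold higher number from compound 3 to compound 4 (0.03 log units; within the scatter) and stays within the scatter. For compound 4 the estimated value is 6.5 mL/min/kg with an expected range from 3.5 mL/min/kg to 12 mL/min/kg in this series.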

Compound 4, clearance: 7 mL/min/kg
Compound 4: middle estimate off by 1.1-fold (0.03 log units), on the low side, and the stated range covers the measured number.
By their numbers in this assay, from the lowest: compounds 3, 4, 1 and 2 (each within the scatter of the next, the first and the last beyond it).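

In this assay the sulfonyl sulfur takes oxan-3-yl, a ring with 1 hetero atom and 1 hydrogen-bond acceptor, without a clear shift from either the carbon-only ring or phenyl: a 1.2-fold higher number from compound 3 to compound 4 (0.07 log units; within the scatter) and a 1.1-fold lower number from compound 1 to compound 4 (0.03 log units; within the scatter) both lie within the scatter. Likewise, a 2.0-fold lower number from compound 2 to compound 4 (0.30 log units; within the scatter) stays within the scatter, so compound 4 does not separate from compound 2, whereas compound 3 does. No measured evidence accounts for these numbers.

Open, from the compounds shown here alone, is whether an amine such as piperidin-4-yl or a carboxylic acid on this ring would stay in the same range. Also open, going by these compounds, is how oxan-4-yl compares with oxan-3-yl on the sulfonyl sulfur.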